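Swapping a Styryl Arm for a Halogenated Biaryl

This account rests on a few compounds, and the source may have more. Where it says the series, first, only, none or still open, it means among the compounds named here.

compound 1 — `COC(=O)/C=C/c1cccc(N(Cc2ccc(/C=C/c3cccc(F)c3)cc2)C(=O)C2CCCCC2)c1` — 86 nM
compound 2 — `COC(=O)/C=C/c1cccc(N(Cc2ccc(/C=C/c3cccc(F)c3)cc2)C(=O)C(C)C)c1` — 71 nM
compound 3 — `COC(=O)/C=C/c1cccc(N(Cc2ccc(-c3cc(Cl)ccc3OC)cc2)C(=O)C(C)C)c1` — 226 nM

Among the three measured compounds, compound 1 stands second highest in an assay on isolated protein with Bile acid receptor (Homo sapiens) as the target (a lower number here means that less compound is needed, a higher number that more compound is needed for the effect), though its nearest neighbour is compound 2, which sits within the scatter of it, with a 1.2-fold lower number from compound 1 to compound 2 (0.08 log units; within the scatter). Compound 3 is furthest away, with the highest number of the set.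

Compound 4 `COC(=O)/C=C/c1cccc(N(Cc2ccc(-c3ccc(F)c(Cl)c3)cc2)C(=O)C2CCCCC2)c1` has not been measured. It differs from compound 1 in one place: 3-chloro-4-fluorophenyl in place of 2-(3-fluorophenyl)ethenyl on an aromatic carbon. The amide substituent, cyclohexyl, is kept.

Within the data shown here, the step that bears on this change is the one from compound 2 to compound 3, where the same styryl arm was replaced by a substituted phenyl directly on the ring and gave a 3.2-fold higher number from compound 2 to compound 3 (0.50 log units; beyond the scatter). The step from compound 1 to compound 2 shows that the amide substituent matters little here. A modest rise of similar size is therefore expected for compound 4 in this assay, with a 2.6-fold higher number from compound 1 to compound 4 (0.41 log units; beyond the scatter). Compound 4 is estimated at 220 nM, within a range of 90 nM to 550 nM.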

Compound 4, half-maximal effective concentration: 66 nM
For compound 4 the middle estimate is 3.3-fold (0.52 log units) above the measured one, outside the stated range (below it).
By their numbers in this assay, from the lowest: compounds 4, 2 and 1 (each within the scatter of the next); then compound 3.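

In this assay, replacing the 2-(3-fluorophenyl)ethenyl group of compound 1 with 3-chloro-4-fluorophenyl gives a 1.3-fold lower number from compound 1 to compound 4 (0.11 log units; within the scatter), so this position, para to a large group, accepts a directly attached halogenated phenyl with no change that can be told from scatter. The rise seen in a 3.2-fold higher number from compound 2 to compound 3 (0.50 log units; beyond the scatter) therefore does not follow from losing the ethenyl link as such: it holds for 5-chloro-2-methoxyphenyl with an isopropyl on the carbonyl, and compound 4 goes against it. No evidence at hand accounts for the difference between these two outcomes.

Compound 3 and compound 4 differ in two places, so the compounds shown do not tell whether the two outcomes follow the substituents on the phenyl ring or the group on the carbonyl. As far as these compounds go, how a carboxylic acid in place of the methyl ester would read alongside 3-chloro-4-fluorophenyl also remains open.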